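Methoxy for pyrazolylmethyl on the seven-membered core

The compounds below may be only part of what the source reports. "The series", "measured", "known", "first", "only" and "open" are said of these compounds alone.

Among the measured compounds shown here, compound 2 `COc1ccc(N(C(=O)CN2C=CN(c3ccccc3)C(=O)C(Cc3cc[nH]n3)(Cc3n[nH]c4ccccc34)C2=O)C(C)C)cc1` is the only member with a single number in a functional assay on CHO cells for agonist activity at Melanocyte-stimulating hormone receptor (Homo sapiens), read by a luciferase reporter, with a stated time of 4 h (a higher number here means that more compound is needed for the effect, a lower number that less compound is needed), giving 398 nM; one further entry lacks a number. Compound 1 `CCn1nc(CC2(OC)C(=O)N(CC(=O)N(c3ccc(OC)cc3)C(C)C)C=CN(c3ccccc3)C2=O)c2ccccc21` gives 31600 nM; > 30000 nM (2 entries) in this assay, its several entries being gathered in the record (the several entries of compound 1 in this assay, 31600 nM; > 30000 nM (2 entries)). Compound 3 `COc1ccc(N(C(=O)CN2C=CN(c3ccccc3)C(=O)C(Cc3n[nH]c4ccccc34)(OC)C2=O)C(C)C)cc1` is not yet measured; it differs from compound 2 by methoxy in place of (1H-pyrazol-3-yl)methyl on a saturated ring carbon. A loss beyond the scatter is expected, a 7.5-fold higher number from compound 2 to compound 3 (0.88 log units; beyond the scatter). Compound 3 is estimated at 3000 nM, within 800 nM to 12000 nM.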

Compound 3, half-maximal effective concentration: 1380 nM
The estimate for compound 3 lay 2.2-fold (0.34 log units) above the measured number, within the range that was stated.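

In this assay, methoxy in place of (1H-pyrazol-3-yl)methyl gives a 3.5-fold higher number from compound 2 to compound 3 (0.54 log units; beyond the scatter), so this saturated ring carbon keeps a measurable response after losing the five-membered aromatic ring and its hydrogen-bond donor. The cost of this change is modest. Compound 1, which also carries methoxy on this carbon, has limits of the assay among its entries: the several entries of compound 1 in this assay, 31600 nM; > 30000 nM (2 entries)

This single step cannot separate the contributions of the ring, the donor and the heavy-atom count. From the compounds shown here alone, how an amine or a longer carbon chain on this carbon would read remains open.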